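Amide-linked aryl amine variation on a sulfamate core

The source may report more compounds than this note shows. Statements on the series, on what has been measured and on what is new or still open speak of the compounds shown alone.

Of the compounds shown here, three have been measured in an assay on HEK293 cells for inhibition of Steryl-sulfatase (Homo sapiens), tested at 1 uM; on this read-out higher numbers stand for a stronger effect at the one concentration tested and lower numbers for a weaker effect. Compound 1 `CN(C)CCN(CCN(C)C)c1cccc(C(=O)N2CCc3ccc(OS(N)(=O)=O)cc3C2)c1` gives 17.1%. Compound 2 `NS(=O)(=O)Oc1ccc2c(c1)CN(C(=O)c1cccc(N(Cc3ccccc3)Cc3ccco3)c1)CC2`, which carries a benzyl and a furan-2-ylmethyl group on the aryl amine, gives 90.5%. Compound 3 `CCN(Cc1ccccc1)Cc1ccc(CN2CCc3ccc(OS(N)(=O)=O)cc3C2)cc1`, in which the amide is replaced by a benzylic linkage, gives 17%. Compound 1 stands second highest of the three numbers: its value and that of compound 3 lie within the scatter of each other, while compound 2 lies far beyond the scatter above both.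

Compound 4 `CCN(Cc1ccncc1)c1cccc(C(=O)N2CCc3ccc(OS(N)(=O)=O)cc3C2)c1` is not yet measured. It differs from compound 1 in one place: ethyl((pyridin-4-yl)methyl)amino in place of bis(2-(dimethylamino)ethyl)amino on an aromatic carbon. The incoming group carries an aromatic ring, as do both groups on the aryl amine of compound 2, which gives 90.5%. Within the data shown here, on that basis an upward step from compound 1 to compound 4 is expected, of moderate size, since only one of the two groups is aromatic. Compound 4 is estimated at 50%, within 20% to 80%, which means an expected step of a number 32.9 percentage points higher from compound 1 to compound 4 (beyond the scatter).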

Compound 4, a percentage reported as inhibition, at one concentration (the size of the read-out at that concentration, not a potency): 52.8%
The estimate for compound 4 lay 2.8 percentage points below the measured number; low and high end bracket the measured number.
By their numbers in this assay, from the lowest: compounds 3 and 1 (each within the scatter of the next); then compound 4; then compound 2.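

In this assay, the amine substituent on the aromatic carbon is a sensitive point in the amide series: ethyl((pyridin-4-yl)methyl)amino in place of bis(2-(dimethylamino)ethyl)amino gives a number 35.7 percentage points higher from compound 1 to compound 4 (beyond the scatter) with the shared core unchanged. Among these compounds, this is the first comparison that differs in one place, and it shows a large step with little change in group size, while a ring-free group gives way to one six-membered aromatic ring with 1 hetero atom. Nothing available explains the step.

From the compounds shown here alone, whether the pyridine nitrogen or the aromatic ring alone goes with the step stays open, and a plain benzyl in place of the (pyridin-4-yl)methyl would separate the two. Also open, going by these compounds, is how a propyl chain in place of the ethyl, or a morpholine as the whole amine, would read here.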